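The source may report more compounds than this note shows. Statements on the series, on what has been measured and on what is new or still open speak of the compounds shown alone.

Measured so far in a functional assay on BJAB cells (Homo sapiens) for antiproliferative activity, with a stated time of 4 days; a lower number here means that less compound is needed, a higher number that more compound is needed for the effect:
compound 1, `Cc1nn(-c2nc(-c3ccc(Cl)c(Cl)c3)c(SC(C)C)s2)c(C(=O)O)c1-c1cccc(Cl)c1C`, gives 5100 nM
compound 2, `Cc1nn(-c2nc(-c3ccc(Cl)c(Cl)c3)c(SC(C)C)s2)c(C(=O)O)c1-c1cccnc1`, gives 12000 nM
compound 3, `Cc1nn(-c2nc(-c3ccc(Cl)c(Cl)c3)c(SC(C)C)s2)c(C(=O)O)c1-c1cncc(C#N)c1`, gives 20000 nM

Compound 3 stands at the highest number of the three, though the nearer of the two steps leading up to it lies within the scatter: a 1.7-fold higher number from compound 2 to compound 3 (0.22 log units; within the scatter). Compound 4, `Cc1nn(-c2nc(-c3ccc(Cl)c(Cl)c3)c(SC(C)C)s2)c(C(=O)O)c1-c1ccccc1[N+](=O)[O-]`, differs from compound 3 in one place: 2-nitrophenyl in place of 5-cyanopyridin-3-yl on an aromatic carbon. The step that bears most on this is a 3.9-fold higher number from compound 1 to compound 3 (0.59 log units; beyond the scatter), since compound 1 also carries a six-membered aromatic ring of carbon only with substituents at the same place, and its number is the lowest shown. The step of a 1.7-fold higher number from compound 2 to compound 3 (0.22 log units; within the scatter) adds little. A return toward compound 1 is therefore expected, with a 2.9-fold lower number from compound 3 to compound 4 (0.46 log units; beyond the scatter). Compound 4 is estimated at 7000 nM, in a range from 3000 nM to 18000 nM.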

Compound 4, half-maximal effective concentration: 4700 nM
Estimate against measurement, compound 4: 1.5-fold (0.17 log units) above, within the range that was stated.
By their numbers in this assay, from the lowest: compounds 4 and 1 (each within the scatter of the next); then compounds 2 and 3 (each within the scatter of the next).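

In this assay, two quite different substituted rings of carbon only at this place give values that cannot be told apart: 2-nitrophenyl replaces 3-chloro-2-methylphenyl with a 1.1-fold lower number from compound 1 to compound 4 (0.04 log units; within the scatter). Against the rings that contain nitrogen, 2-nitrophenyl repeats the gap seen with compound 1, with a 2.6-fold lower number from compound 2 to compound 4 (0.41 log units; beyond the scatter) and a 4.3-fold lower number from compound 3 to compound 4 (0.63 log units; beyond the scatter), so among these four compounds both carbon-only rings give lower numbers than both pyridine rings. Nothing available explains this split.

From the compounds shown here alone, it remains open whether an unsubstituted phenyl ring would group with compound 1 and compound 4. Also open, going by these compounds, is how a phenyl ring carrying an amine or a methoxy group would behave.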